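This account rests on a few compounds, and the source may have more. Where it says the series, first, only, none or still open, it means among the compounds named here.

Compound 1 `O=C(NC(=S)Nc1ccc(Oc2ccccc2)cc1)c1ccccc1` gives 2100 nM in an assay for inhibition of epoxide hydrolase 1 (Homo sapiens), read by fluorescence, using microsomes; on this read-out higher numbers stand for weaker inhibition and lower numbers for stronger inhibition. Compound 2 `CC(=O)NC(=S)Nc1ccc(Oc2ccccc2)cc1` gives 3700 nM in this assay. Compound 3 `O=C(NC(=S)Nc1ccccc1)c1ccccc1` gives 1290 nM in this assay.

Compound 4 `CC(=O)NC(=S)Nc1ccccc1` is not yet measured. It differs from compound 3 by methyl in place of phenyl on a carbonyl carbon. The same change has been made once before, from compound 1 to compound 2, as methyl in place of phenyl on a carbonyl carbon, and that step was a 1.8-fold higher number from compound 1 to compound 2 (0.25 log units; within the scatter). The two cores differ as well: compound 3 differs from compound 1 by hydrogen in place of phenoxy on an aromatic carbon, with a step of a 1.6-fold lower number from compound 1 to compound 3 (0.21 log units; within the scatter). For compound 4 a step of a 1.8-fold higher number from compound 3 to compound 4 (0.25 log units; within the scatter) is expected, resting on the earlier step of a 1.8-fold higher number from compound 1 to compound 2 (0.25 log units; within the scatter) that the same change gave. The estimate for compound 4 in this assay is 2300 nM, expected to lie between 1000 nM and 5500 nM.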

Compound 4, half-maximal inhibitory concentration: 2350 nM
Estimate against measurement, compound 4: 1.0-fold (0.01 log units) below; the range from low to high includes it.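

Putting methyl in place of phenyl on a carbonyl carbon gives a 1.8-fold higher number from compound 3 to compound 4 (0.26 log units; within the scatter) in this assay, and this step matches the one seen on the other core: the same change on two cores in this assay, a 1.8-fold higher number (0.25 log units; within the scatter) from compound 1 to compound 2 and a 1.8-fold higher number (0.26 log units; within the scatter) from compound 3 to compound 4, 1.0-fold (0.01 log units) apart, within the scatter of two such steps. Within these four compounds, then, the change carries over from one core to the other at the same size. Each step on its own lies within the scatter, however, which leaves open whether the change alters inhibition at all, and two cores cannot promise the same result on a third.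

The compounds shown leave open what other groups on this carbonyl carbon would do, such as a longer chain or an amine. They also leave open whether the match holds with a group such as methoxy in place of phenoxy on the aromatic carbon.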